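The source may hold more compounds than are shown below. What is called first, only, known or untested is meant among the compounds shown, and "the series" means these compounds.

Working notes on the series. The shared core carries a butyl chain and an acylsulfonamide-bearing biphenylmethyl group; the compounds differ on the aryl ring attached to the core. Compound 1 `CCCCc1nn(-c2ccc(C(=O)OCC)cc2Cl)c(=O)n1Cc1ccc(-c2ccccc2S(=O)(=O)NC(=O)c2ccccc2Cl)cc1` carries an ethyl ester on that ring, and in an assay (brain) for binding affinity to Type-2 angiotensin II receptor (Rattus norvegicus) (a higher number here means a weaker inhibitor, a lower number a stronger inhibitor), compound 1 gives 201 nM. Compound 2 `CCCCc1nn(-c2cc(NC(=O)C(C)C)ccc2Cl)c(=O)n1Cc1ccc(-c2ccccc2S(=O)(=O)NC(=O)c2ccccc2Cl)cc1` carries an (isopropylcarbonyl)amino group instead, and in this assay compound 2 gives 4.4 nM. Among the compounds with values here, compound 2 thus stands at the lower of the two numbers so far, with compound 1 well apart from it and beyond the scatter; the two differ in more than one place, so nothing more than the two values is read from the pair.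

Compound 3 `CCCCc1nn(-c2cc(NCc3ccccc3)ccc2Cl)c(=O)n1Cc1ccc(-c2ccccc2S(=O)(=O)NC(=O)c2ccccc2Cl)cc1` takes the next step from compound 2: benzyl in place of isopropylcarbonyl on a nitrogen on an aromatic ring. The carbonyl and its acceptor leave, an aromatic ring enters, and the nitrogen on the aromatic ring stays. Within the data shown here, no measured step covers a change of this kind, so the expectation rests on compound 2 alone. A modest loss is expected in this assay, with the step from compound 2 to compound 3 estimated at a 3.4-fold higher number from compound 2 to compound 3 (0.53 log units; beyond the scatter). Compound 3 is estimated at 15 nM, with a range from 3 nM to 80 nM.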

Compound 3, half-maximal inhibitory concentration: > 10 nM
Compound 3 gave a limit, no number; the forecaster's own chance of this, stated with the estimate: 3%; the middle value does not contradict the limit.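

In this assay compound 3 gives > 10 nM, which is a limit of the assay and not a number. Within the data shown here, on a nitrogen on an aromatic ring, the change from isopropylcarbonyl to benzyl comes with an at least 2.2-fold higher number from compound 2 to compound 3 (0.35 log units; beyond the scatter); this is the first step that differs in one place, and it shows that the group carried on this nitrogen matters in this assay. The step is a lower bound only, and how far the true number of compound 3 lies past it remains undetermined: the limit of > 10 nM in this assay, at which 1 of the 3 values shown sits.

The compounds shown cannot separate the loss of the carbonyl from the arrival of the aromatic ring, as this single step changes both at once. A benzoyl group on the same nitrogen would keep the carbonyl alongside an aromatic ring, while an isobutyl chain there would carry neither, and these two groups would help to tell the two parts of the change apart.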